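The compounds below may be only part of what the source reports. "The series", "measured", "known", "first", "only" and "open" are said of these compounds alone.

Compound 1, `O=C1C=CC2(C=C1)OCC(=O)N2c1nc(-c2ccc3ncccc3c2)nn1-c1ccccc1`: 50 nM
Compound 2, `CC1CN(c2nc(-c3ccc4ccccc4c3)nn2-c2ccccc2)C2(C=CC(=O)C=C2)O1`: 130 nM

In a functional assay on MDA-MB-231 cells (Homo sapiens) for antiproliferative activity, with a stated time of 5 days (on this read-out lower numbers stand for stronger inhibition and higher numbers for weaker inhibition), compound 1 gives the lower of these two numbers, and compound 2, which carries naphthalen-2-yl on a core that differs from that of compound 1, sits beyond the usual scatter above it. Compound 3, `O=C1C=CC2(C=C1)OCC(=O)N2c1nc(-c2ccc3ccccc3c2)nn1-c1ccccc1`, keeps the core of compound 1 and changes one group: naphthalen-2-yl in place of quinolin-6-yl on an aromatic carbon. Because compound 2 gives 130 nM with the same naphthalen-2-yl group, a modest loss is expected, probably near the edge of the scatter. For compound 3 a step of a 1.8-fold higher number from compound 1 to compound 3 (0.26 log units; within the scatter) is expected. Compound 3 is estimated at 90 nM, with a range from 35 nM to 250 nM.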

Compound 3, half-maximal inhibitory concentration: 70 nM
Compound 3: middle estimate off by 1.3-fold (0.11 log units), on the high side, and the stated range covers the measured number.
By their numbers in this assay, from the lowest: compounds 1, 3 and 2 (each within the scatter of the next, the first and the last beyond it).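

With the core of compound 1 held fixed, putting naphthalen-2-yl in place of quinolin-6-yl gives a 1.4-fold higher number from compound 1 to compound 3 (0.15 log units; within the scatter). The ring nitrogen and the one hydrogen-bond acceptor of quinolin-6-yl can therefore be exchanged for carbon at this position without a change that can be told from scatter. No measurement shown offers an explanation for this result.

Going by these compounds, what stays open is whether this carbon accepts a group other than these two fused aromatic rings, such as a single pyridine ring, an amine or a carboxylic acid.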